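The source may report more compounds than this note shows. Statements on the series, on what has been measured and on what is new or still open speak of the compounds shown alone.

In a functional assay on SK-N-MC cells (Homo sapiens) for cytotoxicity, read by MTT assay (a higher number here means a weaker inhibitor, a lower number a stronger inhibitor), three compounds have been measured so far. Compound 1 `COc1ccc(/C=C2\CCC/C(=C\c3ccccc3[N+](=O)[O-])C2=O)cc1` gives 75 ug/mL. Compound 2 `COc1cccc(/C=C2\CCC/C(=C\c3cccc([N+](=O)[O-])c3)C2=O)c1OC` gives 10.1 ug/mL, and compound 3 `COc1cc(/C=C2\CCC/C(=C\c3cccc([N+](=O)[O-])c3)C2=O)cc(Br)c1OC` gives 16.7 ug/mL. Among these three numbers compound 3 stands second highest. Its value and that of compound 2 lie within the usual scatter of each other, so the two cannot be told apart on the numbers alone, while the number for compound 1 sits beyond the scatter and is clearly higher, meaning compound 1 is the weaker inhibitor of that pair.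

Compound 4 `CCCCOc1c(Br)cc(/C=C2\CCC/C(=C\c3cccc([N+](=O)[O-])c3)C2=O)cc1OC` has not yet been measured in this assay. It differs from compound 3 in one place: propyl in place of hydrogen on a saturated chain carbon bound to an oxygen on an aromatic ring. Among the compounds with values here, no pair of measured compounds shows a change of this kind, so the data give no precedent for how large a step it brings or in which direction. Without such a precedent, the expected step is a 1.1-fold lower number from compound 3 to compound 4 (0.05 log units; within the scatter), a change not clearly beyond the scatter either way. Compound 4 is therefore expected to give about 15 ug/mL in this assay, with a plausible range from 6 ug/mL to 40 ug/mL.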

Compound 4, half-maximal inhibitory concentration: 25.4 ug/mL
Estimate against measurement, compound 4: 1.7-fold (0.23 log units) below, and the stated range covers the measured number.
By their numbers in this assay, from the lowest: compounds 2, 3 and 4 (each within the scatter of the next, the first and the last beyond it); then compound 1.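

Within the data shown here, compound 3 and compound 4 are the only measured pair that differ in one place, and in this assay they show a 1.5-fold higher number from compound 3 to compound 4 (0.18 log units; within the scatter) for the change from methoxy to butoxy. This step lies within the scatter, so the change cannot be said to shift the number in either direction. At this position, then, propyl in place of hydrogen leaves a number that repeated measurement could not tell apart, and no independent data bear on this result.

This single step does not show how a chain longer than butoxy, or an amine or a carboxylic acid at the end of the chain, would read at this position. Going by these compounds, whether the same change from methoxy to butoxy would give a similar step on compound 2 also stays open.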